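The source may hold more compounds than are shown below. What is called first, only, known or untested is meant among the compounds shown, and "the series" means these compounds.

Compound 3 `Nc1scc(CN2CCN(c3c(F)cccc3F)CC2)c1C(=O)c1ccc(Cl)cc1` holds the lowest number of the three measured in a functional assay on CHO cells with adenosine receptor A1 (Homo sapiens) as the target, read by cAMP accumulation and immunoassay, with a stated time of 6 min, tested at 10 uM (a lower number here means a stronger effect, a higher number a weaker effect of the compound at the concentration tested), where compound 3 gives -80%. Its nearest neighbour is compound 1 `Nc1scc(CN2CCN(c3ccc(Cl)c(C(F)(F)F)c3)CC2)c1C(=O)c1ccc(Cl)cc1`, which in this assay gives -60%, and its furthest is compound 2 `Nc1scc(CN2CCN(c3cccc4ccccc34)CC2)c1C(=O)c1ccc(Cl)cc1`, which in this assay gives -21%. The steps between them all turn on the group carried by the amine nitrogen in the ring: a number 20 percentage points lower from compound 1 to compound 3 (beyond the scatter), a number 59 percentage points lower from compound 2 to compound 3 (beyond the scatter) and a number 39 percentage points higher from compound 1 to compound 2 (beyond the scatter).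

Compound 4 `Nc1scc(CN2CCN(c3cc(Cl)ccc3Cl)CC2)c1C(=O)c1ccc(Cl)cc1` differs from compound 3 by one change, (2,5-dichlorophenyl in place of 2,6-difluorophenyl on an amine nitrogen in a ring). All three measured steps bear on it, since each exchanges the group on that same nitrogen. The two halogenated phenyls of compound 1 and compound 3 sit close together, while the naphthalen-1-yl of compound 2 stands far higher; a 2,5-dichlorophenyl is another halogenated phenyl, so the expectation is a number near those of compound 1 and compound 3 rather than of compound 2. Within the usual scatter, or at most a modest rise toward compound 1, is expected, giving an expected step of a number 10 percentage points higher from compound 3 to compound 4 (within the scatter). Compound 4 is therefore estimated at -70% in this assay, with a range from -95% to -40%.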

Compound 4, a percentage reported as activity, at one concentration (the size of the read-out at that concentration, not a potency): -62%
Compound 4: the middle estimate sits 8 percentage points below what was measured; the range from low to high includes it.
By their numbers in this assay, from the lowest: compound 3; then compounds 4 and 1 (each within the scatter of the next); then compound 2.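

Working notes on the group carried by the amine nitrogen, read in this assay: a halogenated phenyl does not by itself fix the number, since the 2,5-dichlorophenyl of compound 4 parts from the 2,6-difluorophenyl of compound 3 (a number 18 percentage points higher from compound 3 to compound 4 (beyond the scatter)), leaving compound 3 alone at the lowest number of the series. The 2,5-dichlorophenyl and the 4-chloro-3-(trifluoromethyl)phenyl cannot be told apart here (a number 2 percentage points lower from compound 1 to compound 4 (within the scatter)), so two differently substituted chlorine-bearing phenyls give one level, with compound 3 as the exception among the halogenated phenyls, while the naphthalen-1-yl of compound 2 remains well separated from this level (a number 41 percentage points lower from compound 2 to compound 4 (beyond the scatter)). No measurement at hand accounts for these differences.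

The step to compound 4 exchanges fluorine for chlorine and moves the halogens in a single change, so the compounds shown leave the two effects unseparated; a 2,6-dichlorophenyl or a 2,5-difluorophenyl on the same nitrogen would divide them. Also open, as far as these compounds go, is how an unsubstituted phenyl, or a phenyl carrying an amine or a carboxylic acid, would read against these halogenated groups.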